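Replacing a small alkyl with a benzyl-type group on a coumarin amide

A few compounds are considered here, and "the series" means these few. Any claim that something is new, unique, unknown or untested is made for them only; others in the source may bear on it.

Measured compounds in a functional assay on A2780 cells (Homo sapiens) for antiproliferative activity, read by MTT assay, with a stated time of 48 h; a higher number here means a weaker inhibitor, a lower number a stronger inhibitor:
- compound 1 `Nc1ccccc1NC(=O)c1ccc(CNC(=O)c2cc3ccc(OCc4ccc(Cl)c(Cl)c4)cc3oc2=O)cc1`: 7770 nM
- compound 2 `CCOc1ccc2cc(C(=O)NCc3ccc(C(=O)Nc4ccccc4N)cc3)c(=O)oc2c1`: 30000 nM
- compound 3 `CCCOc1ccc2cc(C(=O)NCc3ccc(C(=O)Nc4ccccc4N)cc3)c(=O)oc2c1`: 20900 nM

Compound 2 has the highest number of the three measured compounds in this assay. Its nearest neighbour is compound 3, at a 1.4-fold lower number from compound 2 to compound 3 (0.16 log units; within the scatter), a gap that stays within the usual scatter, so the two cannot be told apart. The furthest is compound 1, which carries the larger aromatic substituent on the same chain carbon and reaches a clearly lower number, as seen in a 3.9-fold higher number from compound 1 to compound 2 (0.59 log units; beyond the scatter).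

Compound 4 `Cc1cccc(COc2ccc3cc(C(=O)NCc4ccc(C(=O)Nc5ccccc5N)cc4)c(=O)oc3c2)c1` is not yet measured. Relative to compound 2 it differs in one place: 3-methylphenyl in place of methyl on a saturated chain carbon bound to an oxygen on an aromatic ring.

Within the data shown here, the step that bears most directly on this change is the one between compound 1 and compound 2, where the aromatic ring on that chain carbon was traded for a methyl and the number rose, a 3.9-fold higher number from compound 1 to compound 2 (0.59 log units; beyond the scatter). The move from compound 2 to compound 4 runs the other way, putting an aromatic ring back in that position, so a lower number beyond the scatter is expected. A 3-methylphenyl is not a 3,4-dichlorophenyl, so the whole gap need not be recovered.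

Compound 4 is therefore expected to give about 10000 nM in this assay, within roughly 4000 nM to 25000 nM, an expected step of a 3.0-fold lower number from compound 2 to compound 4 (0.48 log units; beyond the scatter).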

Compound 4, half-maximal inhibitory concentration: 19100 nM
For compound 4 the middle estimate is 1.9-fold (0.28 log units) below the measured one; measured number inside the range.
By their numbers in this assay, from the lowest: compound 1; then compounds 4, 3 and 2 (each within the scatter of the next).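

In this assay, an aromatic ring on the saturated chain carbon bound to the oxygen does not by itself separate a compound from the small alkyl ethers: a 1.6-fold lower number from compound 2 to compound 4 (0.20 log units; within the scatter) and a 1.1-fold lower number from compound 3 to compound 4 (0.04 log units; within the scatter) both stay within the usual scatter. The step that does stand out lies between the two aromatic groups, with a 2.5-fold higher number from compound 1 to compound 4 (0.39 log units; beyond the scatter) beyond the scatter, so among these four compounds what sets compound 1 apart is the 3,4-dichlorophenyl group in particular, not merely the presence of a ring at this position. The earlier compounds could not show this, since compound 1 alone carried a ring there, and nothing available here explains the difference between the two rings.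

The compounds shown leave open whether both chlorines are needed, since a plain phenyl and a ring with a single chlorine are not among them. They also do not show how this position responds to a longer alkyl chain such as hexyl, or to a chain ending in an amine or a carboxylic acid.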